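A few compounds are considered here, and "the series" means these few. Any claim that something is new, unique, unknown or untested is made for them only; others in the source may bear on it.

In a functional assay on SMMC-7721 cells (Homo sapiens) for antiproliferative activity, read by MTT assay, with a stated time of 48 h (on this read-out lower numbers stand for stronger inhibition and higher numbers for weaker inhibition), three compounds that share one core have been measured, and they differ only in the group on a saturated chain carbon bound to a double-bonded ring carbon. Compound 1 `COC/C1=C/C[C@](C)(CCC=C(C)C)/C=C/[C@@H](OC(=O)C=C(C)C)[C@](C)(O)/C=C/C1=O`, which carries methoxy there, gives 11000 nM. Compound 2 `CC(C)=CCC[C@]1(C)/C=C/[C@@H](OC(=O)C=C(C)C)[C@](C)(O)/C=C/C(=O)/C(CN2CCCC2)=C\C1`, with pyrrolidin-1-yl, gives 140 nM. Compound 3 `CC(C)=CCC[C@]1(C)/C=C/[C@@H](OC(=O)C=C(C)C)[C@](C)(O)/C=C/C(=O)/C(CN2CCN(C)CC2)=C\C1`, with 4-methylpiperazin-1-yl, gives 2940 nM, the second highest of the three numbers.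

Compound 4 `CC(C)=CCC[C@]1(C)/C=C/[C@@H](OC(=O)C=C(C)C)[C@](C)(O)/C=C/C(=O)/C(COC(=O)c2ccc([N+](=O)[O-])cc2)=C\C1` changes the same place: ((4-nitrophenyl)carbonyl)oxy in place of 4-methylpiperazin-1-yl on a saturated chain carbon bound to a double-bonded ring carbon. In words, ((4-nitrophenyl)carbonyl)oxy stands in place of 4-methylpiperazin-1-yl.

All three measured steps bear on this change. Swapping methoxy for pyrrolidin-1-yl gives a 79-fold lower number from compound 1 to compound 2 (1.90 log units; beyond the scatter), and swapping it for 4-methylpiperazin-1-yl gives a 3.7-fold lower number from compound 1 to compound 3 (0.57 log units; beyond the scatter). Exchanging the two rings gives a 21-fold higher number from compound 2 to compound 3 (1.32 log units; beyond the scatter). The number clearly responds to this group, but no group like the incoming one has been measured here, so any forecast is loose.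

The incoming group is joined through oxygen, as methoxy is in compound 1 at 11000 nM, so a modest rise toward that number is expected, not a large step. The expected change is a 2.4-fold higher number from compound 3 to compound 4 (0.38 log units; beyond the scatter). For compound 4 the estimated value is 7000 nM, with an expected range from 1500 nM to 30000 nM.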

Compound 4, half-maximal inhibitory concentration: 2560 nM
Estimate against measurement, compound 4: 2.7-fold (0.44 log units) above; low and high end bracket the measured number.
By their numbers in this assay, from the lowest: compound 2; then compounds 4 and 3 (each within the scatter of the next); then compound 1.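

In this assay, the swap at this position gives a 1.1-fold lower number from compound 3 to compound 4 (0.06 log units; within the scatter), so a group bearing an aromatic ring of carbon only and a group bearing a non-aromatic ring with two nitrogens cannot be told apart here. Attachment through oxygen alone does not fix the number either: on that same oxygen, (4-nitrophenyl)carbonyl in place of methyl gives a 4.3-fold lower number from compound 1 to compound 4 (0.63 log units; beyond the scatter), so what is carried on the oxygen matters as well. Pyrrolidin-1-yl still stands clearly apart from the new group, with an 18-fold higher number from compound 2 to compound 4 (1.26 log units; beyond the scatter), and nothing measured here accounts for any of these differences.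

From the compounds shown here alone, it remains open whether the low number of compound 2 is particular to pyrrolidin-1-yl or extends to other ring amines, such as piperidine or morpholine attached through their nitrogen. Going by these compounds, it also remains open what the nitro group contributes to compound 4, a question that a plain benzoyl group or an acetyl group on the same oxygen would address.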